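The source may report more compounds than this note shows. Statements on the series, on what has been measured and on what is new or still open speak of the compounds shown alone.

Compound 1, whose structure is `CO[C@@H]1[C@@H](OC)[C@H](c2ccccc2)O[C@@H]2CO[C@@H](c3ccccc3)O[C@@H]12`, gives "not determined" (no result reported) in a functional assay on HEL cells (Homo sapiens) for cytotoxicity; a higher number here means that more compound is tolerated, a lower number that less compound is tolerated; nothing was reported for it, so it gives no single number to stand on. Two related compounds do carry numbers. Compound 2, with structure `O=[N+]([O-])c1ccc([C@@H]2OC[C@H]3O[C@@H](c4ccccc4)[C@H](O)[C@@H](O)[C@@H]3O2)cc1`, gives 50 ug/mL in this assay. Compound 3, with structure `CO[C@@H]1[C@@H](OC)[C@H](c2ccccc2)O[C@@H]2CO[C@@H](C3CCCCC3)O[C@@H]12`, gives 20 ug/mL in this assay. The two values lie a little apart, yet with only two points no trend across the set can be drawn from them.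

Compound 4, with structure `CO[C@@H]1[C@@H](OC)[C@H](c2ccccc2)O[C@@H]2CO[C@@H](c3cccc(Cl)c3)O[C@@H]12`, is the compound that has not been tested. It differs from compound 1 by chloro in place of hydrogen on an aromatic carbon, the entering group sitting on an aromatic carbon of a six-membered aromatic ring of carbon only, meta to a large group. Within the data shown here, no step between measured compounds matches this change, so the direction of any shift in this assay cannot be read from the data; the expectation is that compound 4 lands near the two measured values. Compound 4 is estimated at 30 ug/mL in this assay, with a range from 10 ug/mL to 100 ug/mL.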

Compound 4, minimum cytotoxic concentration: >= 40 ug/mL
Compound 4 was reported as a limit; the forecaster's own chance of this, stated with the estimate: 20%; middle value at least 1.3-fold (0.12 log units) from the limit.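

In this assay, among these compounds, compound 4 gives >= 40 ug/mL, which is a limit of the assay and not a number, and the set holds only one reading of this kind: the limit of >= 40 ug/mL in this assay, at which 1 of the 4 values shown sits. Among the compounds shown here, with 3-chlorophenyl in place of cyclohexyl, the data give an at least 2.0-fold higher number from compound 3 to compound 4 (0.30 log units; that floor lies within the scatter), so this position now has a first reading for chloro on an aromatic carbon, although the floor of that step does not go beyond the usual scatter. The change from phenyl to 3-chlorophenyl itself cannot be read, since compound 1 has no reported value.

From the compounds shown here alone, how far the true value of compound 4 lies past its limit remains open, and so does the size of any real gap to compound 3. Also open, going by these compounds, is how this assay would respond to an amine or a carboxylic acid in place of chloro on this ring.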